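This account rests on a few compounds, and the source may have more. Where it says the series, first, only, none or still open, it means among the compounds named here.

Measured so far in a physicochemical assay for lipophilicity (a lower number here means a more polar compound, a higher number a more lipophilic compound), for this series:
compound 1 `CNC(=O)c1cc(C(=O)NC2CCOCC2)n([C@@H](C)c2ccccc2)n1` with 3.6
compound 2 `CNC(=O)c1cc(C(=O)N[C@H]2CC[C@H](O)CC2)n([C@@H](C)c2ccccc2)n1` with 2.9

Compound 2 has the lower number of the two at 2.9 and the gap to compound 1 lies beyond the scatter. The next structure is compound 3 `CNC(=O)c1cc(C(=O)N[C@H]2CC[C@H](OC)CC2)n([C@@H](C)c2ccccc2)n1` with the change methyl in place of hydrogen on an oxygen on a saturated carbon turning 4-hydroxycyclohexyl into 4-methoxycyclohexyl.

Going by the values given here, no measured pair carries this exact change. Among the compounds with values here, the one step that bears on it is a number 0.70 log units lower from compound 1 to compound 2 (beyond the scatter) and it is a modest step beyond the scatter, seen when 4-hydroxycyclohexyl took the place of oxan-4-yl on an amide-type nitrogen. Compound 3 carries no hydroxy group, and neither does compound 1 at 3.6 in the same assay, so a modest move to a higher number is expected in this assay and not a change within the scatter. The expected change is a number 0.60 log units higher from compound 2 to compound 3 (beyond the scatter) on this reasoning. For compound 3 the estimated value is 3.5 with an expected range from 3.1 to 3.9 at this stage.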

Compound 3, distribution coefficient: 4.2
The estimate for compound 3 lay 0.70 log units below the measured number; the whole stated range lies below it.
By their numbers in this assay, from the lowest: compound 2; then compound 1; then compound 3.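

Methyl in place of hydrogen on the oxygen gives a number 1.30 log units higher from compound 2 to compound 3 (beyond the scatter) in this assay for one added heavy atom, so this oxygen on the cyclohexyl ring is a sensitive point in the series, and this large step exceeds the modest a number 0.70 log units lower from compound 1 to compound 2 (beyond the scatter) seen earlier on the same amide-type nitrogen. Neither compound 1 nor compound 3 carries a hydroxy group, yet the two do not coincide: the exchange of oxan-4-yl for 4-methoxycyclohexyl gives a number 0.60 log units higher from compound 1 to compound 3 (beyond the scatter) and places compound 3 highest of the three, so the absence of the hydroxy group alone does not fix the number in this set. No supporting data are available to account for the size of either step.

From the compounds shown here alone, whether a longer chain on the oxygen, such as ethoxy, moves the number further in this assay stays open, as does where an amine or a carboxylic acid would stand at this place on the ring. Going by these compounds, all three compounds also share the rest of the core, so it remains unknown whether the methyl step would keep its size with a different group elsewhere on the core.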